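This account rests on a few compounds, and the source may have more. Where it says the series, first, only, none or still open, it means among the compounds named here.

Measured compounds:
- Compound 1, `O=C(Nc1cc(-c2ccccc2)[nH]n1)c1ccc(Br)nc1`: in a functional assay on WM 266-4 cells (Homo sapiens) for antiproliferative activity, read by MTT assay, with a stated time of 48 h (on this read-out lower numbers stand for stronger inhibition and higher numbers for weaker inhibition), compound 1 gives 6730 nM.
- Compound 2, `O=C(Nc1cc(-c2ccccc2)[nH]n1)c1ccc(Cl)nc1`: in this assay compound 2 gives 6430 nM.
- Compound 3, `Cc1ccc(-c2cc(NC(=O)c3ccc(Br)nc3)n[nH]2)cc1`: in this assay compound 3 gives 6780 nM.

All three compounds share an amide that joins a pyrazole carrying a phenyl-type ring to a halogen-bearing pyridine. The three values in this assay sit close together, and none of the differences among them goes beyond the usual scatter of repeated measurements.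

Compound 1 and compound 2 differ only in the halogen on the pyridine ring: chloro in place of bromo on an aromatic carbon. This change gave a 1.0-fold lower number from compound 1 to compound 2 (0.02 log units; within the scatter).

Compound 1 and compound 3 differ in the ring attached to the pyrazole: methyl in place of hydrogen on an aromatic carbon. This change gave a 1.0-fold higher number from compound 1 to compound 3 (0.00 log units; within the scatter).

Compound 4, `Cc1ccc(-c2cc(NC(=O)c3ccc(Cl)nc3)n[nH]2)cc1`, has not yet been measured in this assay. It relates to compound 3 as compound 2 relates to compound 1: chloro in place of bromo on an aromatic carbon. The place of the change is described in the same words in both pairs, so it is the same change made on a core that carries a methyl group rather than a hydrogen. For compound 4 a step of about a 1.0-fold lower number from compound 3 to compound 4 (0.02 log units; within the scatter) is expected, beside the earlier 1.0-fold lower number from compound 1 to compound 2 (0.02 log units; within the scatter), because that earlier step stayed within the scatter and the core change from compound 1 to compound 3 also gave only a 1.0-fold higher number from compound 1 to compound 3 (0.00 log units; within the scatter). Compound 4 is therefore estimated at 6500 nM, with a likely range from 4000 nM to 10500 nM.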

Compound 4, half-maximal inhibitory concentration: 5720 nM
For compound 4 the middle estimate is 1.1-fold (0.06 log units) above the measured one; the range from low to high includes it.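

In this assay, putting chloro in place of bromo on the core that carries the methyl group gave a 1.2-fold lower number from compound 3 to compound 4 (0.07 log units; within the scatter), and this step reads the same as the one on the core without the methyl group: the same change on two cores in this assay, a 1.0-fold lower number (0.02 log units; within the scatter) from compound 1 to compound 2 and a 1.2-fold lower number (0.07 log units; within the scatter) from compound 3 to compound 4, 1.1-fold (0.05 log units) apart, within the scatter of two such steps. Putting methyl in place of hydrogen among the chloro compounds gave a 1.1-fold lower number from compound 2 to compound 4 (0.05 log units; within the scatter), and this step likewise matches its counterpart among the bromo compounds: the same change on two cores in this assay, a 1.0-fold higher number (0.00 log units; within the scatter) from compound 1 to compound 3 and a 1.1-fold lower number (0.05 log units; within the scatter) from compound 2 to compound 4, 1.1-fold (0.05 log units) apart, within the scatter of two such steps. These four compounds therefore show that both small changes carry from one core to the other in a limited sense: each stays within the scatter on both cores, but such a comparison of near-zero steps cannot show how a change with a large effect would carry over, or whether the same would hold on any other core.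

On these data alone, it remains open whether any group at these two places can shift the number beyond the scatter, for example an amine or a carboxylic acid in place of the halogen on the pyridine, or a longer chain in place of the methyl on the phenyl-type ring. As far as these compounds go, it also remains open whether the amide or the pyrazole of the shared core matters more to this read-out than either of these two places.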